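Fluoro in place of nitro on the shared core

The source may hold more compounds than are shown below. What is called first, only, known or untested is meant among the compounds shown, and "the series" means these compounds.

Within the data shown here, compound 3 `O=C1C=CC[C@H](/C=C/c2ccc([N+](=O)[O-])cc2)O1` is the one member of this small set with a numerical reading: in a functional assay on MCF7 cells (Homo sapiens) for antiproliferative activity, read by luminescence and CellTiter-Glo, with a stated time of 48 h (a lower number here means a stronger inhibitor, a higher number a weaker inhibitor), compound 3 gives 28800 nM. Compound 1 `COc1ccc(/C=C/[C@H]2CC=CC(=O)O2)cc1` reaches only a limit of the assay, > 100000 nM in this assay. Compound 2 `O=C1C=CC[C@@H](/C=C/c2ccc(F)cc2)O1` likewise stops at a limit, > 100000 nM. Among the measured compounds shown here, the single measured step, an at least 3.4-fold lower number from compound 1 to compound 3 (0.54 log units; beyond the scatter), is thus the only guide, and it is read against (the limit of > 100000 nM in this assay, at which 2 of the 3 values shown sit). Compound 4 `O=C1C=CC[C@H](/C=C/c2ccc(F)cc2)O1` differs from compound 3 by fluoro in place of nitro on an aromatic carbon. The nitro-bearing compound 3 alone gave a number, so taking nitro away is expected to raise the number. Compound 4 is therefore expected to give 100000 nM, with a range from 30000 nM to 300000 nM, which would mean a 3.5-fold higher number from compound 3 to compound 4 (0.54 log units; beyond the scatter), and may well end as a limit again.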

Compound 4, half-maximal inhibitory concentration: 76200 nM
Compound 4: middle estimate off by 1.3-fold (0.12 log units), on the high side; the measured number falls inside the stated range.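

Fluoro on this aromatic carbon still gives a number in this assay, so compound 3 is no longer the only one with a reading. The replacement of nitro by fluoro weakens the compound, and the step is modest: a 2.6-fold higher number from compound 3 to compound 4 (0.42 log units; beyond the scatter). The other two steps start from a limit and give only a floor, an at least 1.3-fold lower number from compound 1 to compound 4 (0.11 log units; that floor lies within the scatter) and an at least 1.3-fold lower number from compound 2 to compound 4 (0.11 log units; that floor lies within the scatter): the limit of > 100000 nM in this assay, at which 2 of the 4 values shown sit. Compound 4 and compound 2 therefore give no measure of what configuration contributes: the fact that compounds 2 and 4 differ only in the configuration as drawn. Going by these compounds, whether an amine, a carboxylic acid or a nitrile on this aromatic carbon would fall nearer compound 3 or compound 4 remains open.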